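The source may report more compounds than this note shows. Statements on the series, on what has been measured and on what is new or still open speak of the compounds shown alone.

Compound 1 `Cc1cccc(CN2CCN(C(=O)CN[C@H]3CCN(S(=O)(=O)Cc4ccccc4)C3)CC2)c1`: 11300 nM
Compound 2 `O=C(CN[C@H]1CCN(S(=O)(=O)Cc2ccccc2)C1)N1CCN(Cc2cccc(Cl)c2)CC1`: 8600 nM
Compound 3 `O=C(CN[C@H]1CCN(S(=O)(=O)Cc2ccccc2)C1)N1CCN(Cc2ccc(Cl)cc2)CC1`: 9200 nM

All three values come from a functional assay on K562 cells (Homo sapiens) for cytotoxicity, read by MTT assay, with a stated time of 48 h; on this read-out higher numbers stand for weaker inhibition and lower numbers for stronger inhibition. Compound 3 stands within the scatter of both other compounds, so the three cannot be ranked. Compound 4 `O=C(CN[C@H]1CCN(S(=O)(=O)Cc2ccccc2)C1)N1CCN(Cc2cccc(F)c2)CC1` differs from compound 3 as follows: 3-fluorophenyl in place of 4-chlorophenyl on a saturated chain carbon bound to an amine nitrogen in a ring. Put briefly, 3-fluorophenyl replaces 4-chlorophenyl on a saturated chain carbon bound to an amine nitrogen in a ring. The measured steps closest to this change are a 1.1-fold higher number from compound 2 to compound 3 (0.03 log units; within the scatter) and a 1.2-fold lower number from compound 1 to compound 3 (0.09 log units; within the scatter), and a 1.3-fold lower number from compound 1 to compound 2 (0.12 log units; within the scatter) also bears on it. For the measured compounds named here, all three lie within the scatter, and no fluoro compound has been measured yet. No step beyond the scatter is therefore expected in this assay.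

The estimated step is a 1.1-fold higher number from compound 3 to compound 4 (0.04 log units; within the scatter).

Compound 4 is expected at 10000 nM, with an estimated range of 6000 nM to 16000 nM.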

Compound 4, half-maximal inhibitory concentration: 13200 nM
Compound 4: the middle estimate sits 1.3-fold (0.12 log units) below what was measured; the range from low to high includes it.
By their numbers in this assay, from the lowest: compounds 2, 3, 1 and 4 (each within the scatter of the next).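

In this assay the fluoro group joins methyl and chloro on the aromatic carbon without a step beyond the scatter, with a 1.5-fold higher number from compound 2 to compound 4 (0.19 log units; within the scatter) for fluoro in place of chloro and a 1.2-fold higher number from compound 1 to compound 4 (0.07 log units; within the scatter) for fluoro in place of methyl. The change from 4-chlorophenyl to 3-fluorophenyl gives a 1.4-fold higher number from compound 3 to compound 4 (0.16 log units; within the scatter) and so the four compounds still cannot be ranked. No supporting evidence bears on this result.

As far as these compounds go, whether an amine or a carboxylic acid on this aromatic ring would give a step beyond the scatter remains open. So does a longer chain in place of the saturated chain carbon.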